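This account rests on a few compounds, and the source may have more. Where it says the series, first, only, none or still open, it means among the compounds named here.

Working notes on the imine series.

Three compounds have numbers in a functional assay on DLD-1 cells (Homo sapiens) for cytotoxicity, read by MTT assay, with a stated time of 72 h; on this read-out higher numbers stand for weaker inhibition and lower numbers for stronger inhibition. Compound 1 `Cc1c(/N=C/c2ccc(N(C)C)cc2)c(=O)n(-c2ccccc2)n1C` gives 871000000 nM. Compound 2 `Cc1c(/N=C/c2ccccc2Cl)c(=O)n(-c2ccccc2)n1C` gives 417000000 nM. Compound 3 `COc1ccc(/C=N/c2c(C)n(C)n(-c3ccccc3)c2=O)cc1OC` gives 676000000 nM. Compound 2 holds the lowest of the three numbers, but the gap to compound 3 lies within the usual scatter, so nothing separates these two; only compound 1 stands beyond the scatter, with a higher number than compound 2. All three numbers sit at the very weak end of this assay.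

Compound 4 `Cc1c(/N=C/c2ccc(Cl)cc2Cl)c(=O)n(-c2ccccc2)n1C` is the next member and has not yet been measured. Relative to compound 2 the change is chloro in place of hydrogen on an aromatic carbon, read one bond further out as 2-chlorophenyl to 2,4-dichlorophenyl. Among the measured compounds shown here, no pair of measured compounds that differ in one place exists in this set, so there is no measured step to lean on. The three measured numbers span a narrow band, and a single added chloro group is not expected to move the number beyond that band; the expected step of a 1.1-fold higher number from compound 2 to compound 4 (0.03 log units; within the scatter) is none beyond the scatter, in no preferred direction. Compound 4 is therefore estimated at 450000000 nM in this assay, with an expected range from 180000000 nM to 1100000000 nM.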

Compound 4, half-maximal inhibitory concentration: 126000000 nM
Beside the measured number, compound 4's estimate is 3.6-fold (0.55 log units) above it; measured number below the stated range.
By their numbers in this assay, from the lowest: compound 4; then compounds 2, 3 and 1 (each within the scatter of the next, the first and the last beyond it).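

Among the compounds shown here, this is the first step that can be read at a single place: in this assay, chloro in place of hydrogen on an aromatic carbon, meta to a chloro group and para to a large group, gives a 3.3-fold lower number from compound 2 to compound 4 (0.52 log units; beyond the scatter) as a modest change beyond the scatter. The earlier compounds shown here could not show that this place on the ring responds at all, since none of them forms a pair differing in one place, whereas the change from 2-chlorophenyl to 2,4-dichlorophenyl now shows that one added chloro group is enough to shift the number in the direction of stronger inhibition. No measurement at hand bears on why the number moves.

Open, going by these compounds, is whether the step belongs to chloro in particular or would also come with fluoro, a methoxy group or an amine at this place. Also open, on these data alone, is whether the step depends on the chloro group already on the ring, a question that a 4-chlorophenyl member would address.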